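Removing a methyl from a piperazine: effect on plasma protein binding

The source may hold more compounds than are shown below. What is called first, only, known or untested is meant among the compounds shown, and "the series" means these compounds.

Compound 1 `CNc1nccc(N2CC[C@H](NC(=O)Nc3ccc(Cl)c(C(F)(F)F)c3)C2)n1` and compound 2 `CCNc1nccc(N2CC[C@H](NC(=O)Nc3ccc(Cl)c(C(F)(F)F)c3)C2)n1` share a core and differ only in the group on the saturated chain carbon bound to a nitrogen on an aromatic ring: hydrogen in place of methyl on a saturated chain carbon bound to a nitrogen on an aromatic ring. In an ADME assay on a cell-free system (plasma, Rattus norvegicus) for protein binding, compound 1 gives 99.7% and compound 2 gives 99.9%, so that a 3.0-fold higher unbound fraction from compound 2 to compound 1 (0.48 log units; beyond the scatter). Compound 3 `CCN1CCN(Cc2ccc(NC(=O)N[C@H]3CCN(c4ccnc(NC)n4)C3)cc2C(F)(F)F)CC1` differs from compound 1 by a (4-ethylpiperazin-1-yl)methyl in place of chloro on an aromatic carbon, and in this assay compound 3 gives 84.2%, with a 53-fold higher unbound fraction from compound 1 to compound 3 (1.72 log units; beyond the scatter). How the core of compound 3 differs from that of compound 2 is not broken down here.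

Compound 4 `CNc1nccc(N2CC[C@H](NC(=O)Nc3ccc(CN4CCN(C)CC4)c(C(F)(F)F)c3)C2)n1` is not yet measured. It differs from compound 3 by hydrogen in place of methyl on a saturated chain carbon bound to an amine nitrogen in a ring. For the measured compounds named here, this is the same kind of change as the one from compound 2 to compound 1, but the place is not the same: there the carbon is bound to a nitrogen on an aromatic ring, here to an amine nitrogen in a ring. Because a 3.0-fold higher unbound fraction from compound 2 to compound 1 (0.48 log units; beyond the scatter) was modest, a modest step is expected for compound 4 too, a 1.3-fold higher unbound fraction from compound 3 to compound 4 (0.10 log units; within the scatter). Compound 4 is expected to give about 80%, between 65% and 91%.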

Compound 4, plasma protein binding in the Rattus norvegicus assay: 85.1%
Compound 4: middle estimate off by 1.3-fold (0.13 log units) (unbound fraction), on the high side, within the range that was stated.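

In the Rattus norvegicus assay, hydrogen in place of methyl on a saturated chain carbon bound to an amine nitrogen in a ring gives a 1.1-fold lower unbound fraction from compound 3 to compound 4 (0.03 log units; within the scatter), while the exchange of chloro for the (4-methylpiperazin-1-yl)methyl group gives a 50-fold higher unbound fraction from compound 1 to compound 4 (1.70 log units; beyond the scatter). The removal of a methyl therefore does not carry over at the same size from one core to the other: the same change on two cores in the Rattus norvegicus assay, a 3.0-fold higher unbound fraction (0.48 log units; beyond the scatter) from compound 2 to compound 1 and a 1.1-fold lower unbound fraction (0.03 log units; within the scatter) from compound 3 to compound 4, 3.2-fold (0.50 log units) apart, beyond the scatter of two such steps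

This shows that a step read on one core is no safe forecast for another, but two pairs cannot show whether the gap comes from the core or from the different place of the carbon. In a physicochemical assay for solubility, measured as kinetic solubility (on this read-out lower numbers stand for lower solubility and higher numbers for higher solubility), compound 3 gives 132000 nM and compound 4 gives 67500 nM, and the same change gives a 2.0-fold lower number from compound 3 to compound 4 (0.29 log units; within the scatter).

The compounds shown leave open how the unbound fraction would respond to a piperazine bearing propyl or 2-hydroxyethyl in place of ethyl. They also leave open whether (4-methylpiperazin-1-yl)methyl in place of chloro would give a similar step on the core of compound 2.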